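Notes on compound 4 against the series so far

A few compounds are considered here, and "the series" means these few. Any claim that something is new, unique, unknown or untested is made for them only; others in the source may bear on it.

Going by the values given here, the series so far holds compound 1 `O=C(N1CCC(c2nc(-c3ccc4ccccc4n3)no2)CC1)N1CCCc2ccccc21`, compound 2 `COc1ccccc1NC(=O)N1CCC(c2noc(-c3ccc4ccccc4n3)n2)CC1` and compound 3 `COc1ccccc1NC(=O)N1CCC(c2nc(-c3ccc4ccccc4n3)no2)CC1`. In a functional assay on Shh Light II cells (Mus musculus) for inhibition, read by a luciferase reporter (on this read-out lower numbers stand for stronger inhibition and higher numbers for weaker inhibition), compound 1 gives 2300 nM, the second highest of the three numbers. Compound 2 gives 2400 nM, within the scatter of compound 1. Compound 3 gives 410 nM. Among the compounds with values here, the only single-point step is a 5.6-fold lower number from compound 1 to compound 3 (0.75 log units; beyond the scatter). Compound 4 `O=C(OCc1ccccc1)N1CCC(c2nc(-c3ccc4ccccc4n3)no2)CC1` differs from compound 1 by benzyloxy in place of 1,2,3,4-tetrahydroquinolin-1-yl on a carbonyl carbon. Within the data shown here, no measured step puts benzyloxy at this carbonyl carbon; the step from compound 1 to compound 3 shows only that the group there can move the number well beyond the scatter. With no closer guide, a step in this assay smaller than that, or none beyond the scatter, is expected. Compound 4 is estimated at 1500 nM (range 400 nM to 6000 nM), an expected 1.5-fold lower number from compound 1 to compound 4 (0.19 log units; within the scatter).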

Compound 4, half-maximal inhibitory concentration: > 2500 nM
Compound 4: only a limit was reported (the forecaster's own chance of this, stated with the estimate: 10%); middle value at least 1.6-fold (0.22 log units) from the limit.
By their numbers in this assay, from the lowest: compound 3; then compounds 1 and 2 (each within the scatter of the next). At a limit, above all of these: compound 4.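

Compound 4 is reported in this assay only as a limit and not as a number: the limit of > 2500 nM in this assay, at which 1 of the 4 values shown sits.

Benzyloxy at this carbonyl carbon gives an at least 6.0-fold higher number from compound 3 to compound 4 (0.78 log units; beyond the scatter), so it does not keep the lower number that (2-methoxyphenyl)amino gives there. Against 1,2,3,4-tetrahydroquinolin-1-yl the change gives an at least 1.0-fold higher number from compound 1 to compound 4 (0.03 log units; that floor lies within the scatter), which shows no gain, while the true size of this step cannot be read from a limit.

Still open, as far as these compounds go, is whether a plain phenylamino group at this carbonyl carbon would hold the number of compound 3, or whether the methoxy group is needed for it. From the compounds shown here alone, an open-chain amine such as diethylamino at the same carbon also remains untested in these notes.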